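Compound 4: pyrrolidin-1-yl in place of cyclopropylmethoxy

A few compounds are considered here, and "the series" means these few. Any claim that something is new, unique, unknown or untested is made for them only; others in the source may bear on it.

Three members of the series have been measured in a functional assay on A549 cells (Homo sapiens) for inhibition, read by sulforhodamine B assay, with a stated time of 48 h; on this read-out higher numbers stand for weaker inhibition of growth and lower numbers for stronger inhibition of growth. Compound 1 `COc1ccc2c(c1)NC(=O)CN2c1nc(NCCCO)nc2ccccc12` gives 5.18 nM, compound 3 `COc1ccc2c(c1)NC(=O)CN2c1nc(Nc2ccc(C#N)cc2)nc2ccccc12` gives 6.17 nM, and compound 2 `COc1ccc2c(c1)NC(=O)CN2c1nc(OCC2CC2)nc2ccccc12` gives 15.8 nM. Compound 2 stands highest of the three numbers, beyond the scatter from both of the others: a 3.1-fold higher number from compound 1 to compound 2 (0.48 log units; beyond the scatter), and a 2.6-fold lower number from compound 2 to compound 3 (0.41 log units; beyond the scatter). The values of compound 1 and compound 3 are within the scatter of each other, a 1.2-fold higher number from compound 1 to compound 3 (0.08 log units; within the scatter).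

Compound 4 `COc1ccc2c(c1)NC(=O)CN2c1nc(N2CCCC2)nc2ccccc12` differs from compound 2 in one place: pyrrolidin-1-yl in place of cyclopropylmethoxy on an aromatic carbon. Both measured steps touching compound 2 bear on this change, since in each the cyclopropylmethoxy group is exchanged for a group attached through nitrogen, and in each the number falls by a modest amount. The entering groups in those steps carry a hydrogen-bond donor, which pyrrolidin-1-yl does not, so the expectation is kept cautious. A modest lower number is expected for compound 4 in this assay, comparable to the two measured steps. Compound 4 is thus estimated at 7 nM, with a range from 2.5 nM to 20 nM. The expected step is a 2.3-fold lower number from compound 2 to compound 4 (0.35 log units; beyond the scatter).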

Compound 4, concentration for 50% growth inhibition: 45 nM
Compound 4: middle estimate off by 6.4-fold (0.81 log units), on the low side, and the stated range ends below it.
By their numbers in this assay, from the lowest: compounds 1 and 3 (each within the scatter of the next); then compound 2; then compound 4.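

In this assay, attachment through nitrogen at this carbon between two ring nitrogen atoms does not by itself lower the number: pyrrolidin-1-yl in place of cyclopropylmethoxy gives a 2.8-fold higher number from compound 2 to compound 4 (0.45 log units; beyond the scatter), the opposite direction to the two earlier exchanges at this position. Replacing the groups that keep a hydrogen on the attaching nitrogen gives a 7.3-fold higher number from compound 3 to compound 4 (0.86 log units; beyond the scatter) and an 8.7-fold higher number from compound 1 to compound 4 (0.94 log units; beyond the scatter), so the two groups with 0 hydrogen-bond donors, cyclopropylmethoxy and pyrrolidin-1-yl, give the two highest numbers, though they also differ from each other. No evidence on the cause of these differences is at hand.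

Going by these compounds, whether the hydrogen on the attaching nitrogen or the rest of the substituent separates these compounds remains open. A cyclopentylamino group, set against pyrrolidin-1-yl, would test this, and a morpholin-4-yl group would show how far a further ring oxygen moves the number.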